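A few compounds are considered here, and "the series" means these few. Any claim that something is new, unique, unknown or untested is made for them only; others in the source may bear on it.

Compounds measured so far in a functional assay on CHO cells for agonist activity at Alpha-1A adrenergic receptor (Homo sapiens), read by FLIPR and calcium flux; on this read-out lower numbers stand for an effect already at smaller amounts and higher numbers for an effect only at larger amounts of compound:

Compound 1, `CCCS(=O)(=O)Nc1cccc2c1CCC2c1ncc[nH]1`, gives 1340 nM.
Compound 2, `CNC(=O)c1cccc2c1CCC2c1ncc[nH]1`, gives 2200 nM.

Among the measured compounds shown here, compound 2 stands with the higher of the two numbers in this assay, but its only neighbour, compound 1, sits a 1.6-fold higher number from compound 1 to compound 2 (0.22 log units; within the scatter), so the two values cannot be told apart. Compound 3, `c1cc(-c2nccs2)c2c(c1)C(c1ncc[nH]1)CC2`, carries a change at the same position: 1,3-thiazol-2-yl in place of methylcarbamoyl on an aromatic carbon. For the measured compounds named here, the one measured step, from a (propylsulfonyl)amino group to methylcarbamoyl, was within the scatter and says little about what a 1,3-thiazol-2-yl group will do there, since no aromatic ring has yet been placed on that carbon. With no guide from the data, compound 3 is expected to stay close to compound 2, with a wide range allowed, a step of a 1.5-fold lower number from compound 2 to compound 3 (0.17 log units; within the scatter). Compound 3 is therefore estimated at 1500 nM, between 300 nM and 7000 nM.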

Compound 3, half-maximal effective concentration: 426 nM
Compound 3: middle estimate off by 3.5-fold (0.55 log units), on the high side; the measured number falls inside the stated range.
By their numbers in this assay, from the lowest: compound 3; then compounds 1 and 2 (each within the scatter of the next).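

In this assay the position on this aromatic carbon now shows a clear response to the group it carries: the earlier pair of groups could not be told apart, whereas 1,3-thiazol-2-yl in place of methylcarbamoyl gives a 5.2-fold lower number from compound 2 to compound 3 (0.71 log units; beyond the scatter) and 1,3-thiazol-2-yl in place of (propylsulfonyl)amino gives a 3.1-fold lower number from compound 1 to compound 3 (0.50 log units; beyond the scatter). Among the compounds shown here, both steps are modest, yet they place compound 3 with the lowest number of the three, and this is the first compound here with a five-membered aromatic ring at this position. Nothing available explains why this change lowers the number.

The compounds shown leave open whether this lower number is particular to 1,3-thiazol-2-yl or would also appear with another ring on the same carbon, such as phenyl, pyridin-2-yl or 1,3-oxazol-2-yl. They also leave open what a small group there, such as an amine or a methyl, would give.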